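One Aromatic Ring for Another on a Shared Core

A few compounds are considered here, and "the series" means these few. Any claim that something is new, unique, unknown or untested is made for them only; others in the source may bear on it.

Compound 2 `O=c1oc2ccccc2c2nc3c(ccc4cc[nH]c43)c(-c3ccccn3)c12` is the reference point. In a functional assay on B16-F10 cells (Mus musculus) for cytotoxicity (a higher number here means a weaker inhibitor, a lower number a stronger inhibitor), compound 2 gives 70700 nM. It shares its core with compound 1 `O=c1oc2ccccc2c2nc3c(ccc4cc[nH]c43)c(-c3ccccc3Br)c12`, and in this assay compound 1 gives 70700 nM, so the step of no change at the digits printed from compound 1 to compound 2 (within the scatter) left the number where it was. Compound 3 `O=c1cc(O)c2cc(F)ccc2o1` is built on a different and much smaller core, and in this assay compound 3 gives 70700 nM. Compound 2 therefore stands level with both other compounds, and none of the three can be called stronger or weaker than another.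

The new compound, compound 4 `COc1ccc(-c2c3ccc4cc[nH]c4c3nc3c2c(=O)oc2ccccc23)cc1`, alters a single group: 4-methoxyphenyl in place of pyridin-2-yl on an aromatic carbon. Among the measured compounds shown here, the only measured step that touches this same place is no change at the digits printed from compound 1 to compound 2 (within the scatter), in which one aromatic ring replaced another without moving the result. For the measured compounds named here, nothing among the measured compounds suggests that this place controls the read-out, so the expected step of no change at the digits printed from compound 2 to compound 4 (within the scatter) is none beyond the scatter. Compound 4 is accordingly estimated at 70700 nM, with a range from 15000 nM to 80000 nM.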

Compound 4, half-maximal inhibitory concentration: 70700 nM
Compound 4: the middle estimate sits on the measured number at the digits printed, and the stated range covers the measured number.
By their numbers in this assay, from the lowest: compounds 1, 2, 3 and 4 (each within the scatter of the next).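

In this assay, putting 4-methoxyphenyl at this position on the shared core gives no change at the digits printed from compound 2 to compound 4 (within the scatter) and no change at the digits printed from compound 1 to compound 4 (within the scatter). The position has now held 2-bromophenyl in compound 1, pyridin-2-yl in compound 2 and 4-methoxyphenyl in compound 4, and the result is the same for all three, so the ring nitrogen of pyridin-2-yl is not needed to keep the number where it stands. Nothing available explains why these three different rings give the same number.

All three groups at this position are single six-membered aromatic rings, so the compounds shown cannot say whether the number would hold with something of another kind there, such as an amine, a carboxylic acid or a longer alkyl chain. They also leave open whether any change at this position can shift the number at all.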